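Benzyl Chlorination Pattern and Cytotoxicity in Compound 4

The source may report more compounds than this note shows. Statements on the series, on what has been measured and on what is new or still open speak of the compounds shown alone.

Measured compounds:
compound 1, `COc1ccc2cc([C@H](C)c3nnc(SCc4c(Cl)cccc4Cl)n3-c3cccc(Cl)c3)ccc2c1`: 165000 nM
compound 2, `COc1ccc2cc([C@H](C)c3nnc(SCc4ccc(Cl)cc4)n3-c3ccc(F)cc3)ccc2c1`: <= 400000 nM
compound 3, `COc1ccc2cc([C@H](C)c3nnc(SCc4ccc(Cl)cc4)n3-c3ccc(Cl)cc3)ccc2c1`: 5800 nM

In a functional assay on PC-3 cells (Homo sapiens) for cytotoxicity, read by MTT assay (on this read-out higher numbers stand for weaker inhibition and lower numbers for stronger inhibition), compound 3 gives 5800 nM, the lowest of the two numbers shown. Compound 1 gives 165000 nM, a higher number beyond the scatter. The value of compound 2 is a limit of the assay, not a number. Going by the values given here, the one step between neighbours, a step that the limit leaves unreadable from compound 2 to compound 3, is therefore unreadable.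

Compound 4, `COc1ccc2cc([C@H](C)c3nnc(SCc4c(Cl)cccc4Cl)n3-c3ccc(Cl)cc3)ccc2c1`, is compound 3 with 2,6-dichlorophenyl in place of 4-chlorophenyl on a saturated chain carbon bound to a sulfur. Among the compounds with values here, no measured step follows this change alone: compound 1 carries the same 2,6-dichlorobenzyl group but differs from compound 4 in a second place as well, so its higher number can only be taken as a loose hint. On that hint alone, a move toward weaker inhibition is expected, of moderate size and with wide uncertainty.

Compound 4 is estimated to give 40000 nM in this assay, within a range from 8000 nM to 200000 nM. The step from compound 3 to compound 4 is thus expected to be a 6.9-fold higher number from compound 3 to compound 4 (0.84 log units; beyond the scatter).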

Compound 4, half-maximal inhibitory concentration: 34700 nM
Compound 4: middle estimate off by 1.2-fold (0.06 log units), on the high side; the range from low to high includes it.
By their numbers in this assay, from the lowest: compound 3; then compound 4; then compound 1.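

In this assay the place on a saturated chain carbon bound to a sulfur now has its first readable step: 2,6-dichlorophenyl in place of 4-chlorophenyl gives a 6.0-fold higher number from compound 3 to compound 4 (0.78 log units; beyond the scatter) and so moves the number beyond the scatter. Compound 4 also opens a second comparison, with the 2,6-dichlorobenzyl group held constant, as 4-chlorophenyl in place of 3-chlorophenyl on an aromatic nitrogen gives a 4.8-fold lower number from compound 1 to compound 4 (0.68 log units; beyond the scatter) and this too lies beyond the scatter. Going by these compounds alone, the one earlier step starts from a limit of the assay and cannot be read, so these are the only two sized changes, and each is modest.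

Going by these compounds, it remains open how an unsubstituted phenyl, a longer chain or an amine would read in place of the chlorinated phenyl on that chain carbon, and whether the higher number of compound 4 follows from the loss of 4-chlorophenyl or the arrival of 2,6-dichlorophenyl. Nothing measured here bears on why either step has the size it has.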